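The source may hold more compounds than are shown below. What is called first, only, known or untested is meant among the compounds shown, and "the series" means these compounds.

Series values in a functional assay on SH-SY5Y cells (Homo sapiens) for cytotoxicity; on this read-out higher numbers stand for weaker inhibition and lower numbers for stronger inhibition:
- compound 1 `c1ccc(-c2ccc(-c3c[nH]c(CCC4CCCCC4)n3)cc2)cc1`: 760 nM
- compound 2 `c1ccc(-c2ccc(-c3c[nH]c(CCCC4CCCCC4)n3)cc2)cc1`: 1000 nM

Compound 2 has only compound 1 for comparison, and the two values lie within the scatter of each other. The next structure is compound 3 `CCCCCCc1nc(-c2ccc(-c3ccccc3)cc2)c[nH]1`, and the change is propyl in place of cyclohexyl on a saturated chain carbon, three bonds along the chain from an aromatic carbon. Among the compounds with values here, one measured step bears on this, a 1.3-fold higher number from compound 1 to compound 2 (0.12 log units; within the scatter), which is a change at the cyclohexyl end of the chain and stays within the scatter. Within the data shown here, no measured compound lacks the cyclohexyl, so the range must stay wide. No shift beyond the scatter is therefore expected in this assay, in either direction. The expected change is a 1.2-fold higher number from compound 2 to compound 3 (0.08 log units; within the scatter). For compound 3 the estimated value is 1200 nM, with an expected range of 500 nM to 3000 nM.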

Compound 3, half-maximal inhibitory concentration: 450 nM
The estimate for compound 3 lay 2.7-fold (0.43 log units) above the measured number; measured number below the stated range.
By their numbers in this assay, from the lowest: compounds 3, 1 and 2 (each within the scatter of the next, the first and the last beyond it).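

In this assay, within the data shown here, the cyclohexyl ring is not needed at this chain end for a number of this size: the open-chain hexyl compound, with propyl in place of cyclohexyl, gives a 2.2-fold lower number from compound 2 to compound 3 (0.35 log units; beyond the scatter) and this is the first step beyond the scatter. Read against the shorter cyclohexyl compound, the same open chain gives a 1.7-fold lower number from compound 1 to compound 3 (0.23 log units; within the scatter) and that step stays within the scatter, so the open chain separates only from the longer ring compound, and only modestly. Nothing at hand accounts for this difference.

From the compounds shown here alone, whether a longer chain or a branched one would carry the numbers further down remains open. So does the effect of an amine or a carboxylic acid at the chain end, since all three compounds end in plain carbon.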